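From Bromo to Fluoro: Little Change Expected

A few compounds are considered here, and "the series" means these few. Any claim that something is new, unique, unknown or untested is made for them only; others in the source may bear on it.

In a functional assay on HCT-116 cells (Homo sapiens) for cytotoxicity, read by MTT assay, with a stated time of 72 h (on this read-out higher numbers stand for weaker inhibition and lower numbers for stronger inhibition), compound 1 (`O=S(=O)(c1ccccc1)c1nc2ccccc2nc1N1CCCC(O)C1`) gives 1390 nM and compound 2 (`Cc1ccc(S(=O)(=O)c2nc3ccccc3nc2N2CCCC(O)C2)cc1`) gives 3270 nM on the same scale. Compound 3 (`O=S(=O)(c1ccc(Br)cc1)c1nc2ccccc2nc1N1CCCC(O)C1`) gives 2110 nM and stands within the scatter of both. Compound 4 (`O=S(=O)(c1ccc(F)cc1)c1nc2ccccc2nc1N1CCCC(O)C1`) has yet to be measured. Its difference from compound 3 is fluoro in place of bromo on an aromatic carbon with fluoro in place of bromo on an aromatic carbon, para to a large group.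

Within the data shown here, no fluoro compound has been measured, so only indirect evidence bears on this change. Two steps reach compound 3: a 1.5-fold higher number from compound 1 to compound 3 (0.18 log units; within the scatter) with bromo in place of hydrogen, and a 1.5-fold lower number from compound 2 to compound 3 (0.19 log units; within the scatter) with bromo in place of methyl. Among the measured compounds shown here, the only step beyond the scatter is a 2.4-fold higher number from compound 1 to compound 2 (0.37 log units; beyond the scatter) with methyl in place of hydrogen, and it is modest. The estimated step is a 1.2-fold lower number from compound 3 to compound 4 (0.09 log units; within the scatter) and no move beyond the scatter is expected in this assay for this change. Compound 4 is expected to give 1700 nM (estimated range 900 nM to 3200 nM).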

Compound 4, half-maximal inhibitory concentration: 5500 nM
Estimate against measurement, compound 4: 3.2-fold (0.51 log units) below; the whole stated range lies below it.
By their numbers in this assay, from the lowest: compounds 1, 3, 2 and 4 (each within the scatter of the next, the first and the last beyond it).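

In this assay, among these compounds, this position proves more sensitive than the earlier compounds showed: going from 4-bromophenyl to 4-fluorophenyl gives (a 2.6-fold higher number from compound 3 to compound 4 (0.42 log units; beyond the scatter)), a modest move, whereas bromo in place of hydrogen had stayed within the scatter. Fluoro in place of hydrogen gives the largest step yet seen at this position (a 4.0-fold higher number from compound 1 to compound 4 (0.60 log units; beyond the scatter)), while fluoro in place of methyl remains within the scatter (a 1.7-fold higher number from compound 2 to compound 4 (0.23 log units; within the scatter)), so compound 2 and compound 4 cannot be told apart here. No measurement at hand accounts for the gap between the fluoro and bromo compounds.

Still open, on these data alone, is how other groups on this aromatic carbon, such as chloro, methoxy or an amine, would read on this scale. As far as these compounds go, it is also open whether the step from bromo to fluoro would hold with a different group in place of the hydroxyl on the shared core.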